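The compounds below may be only part of what the source reports. "The series", "measured", "known", "first", "only" and "open" are said of these compounds alone.

Measured so far:
compound 1, `CCOc1ccc(N/N=C2\CCC(C)n3c2ncc(C(=O)O)c3=O)cc1`, 1.6 umol/kg
compound 2, `CCOc1ccc(N/N=C2\CC[C@H](C)n3c2ncc(C(=O)O)c3=O)cc1`, 100 umol/kg

In a functional assay on the whole organism for inhibition, with Rattus norvegicus as the target (on this read-out higher numbers stand for an effect only at larger amounts of compound and lower numbers for an effect already at smaller amounts), compound 1 gives 1.6 umol/kg, the lowest of the two numbers; the nearest is compound 2, reached by a 63-fold higher number from compound 1 to compound 2 (1.80 log units; beyond the scatter). That step rests on the fact that one of compounds 1 and 2 is drawn with a defined configuration and the other without, at the place where they differ and on nothing else in the structure, since the two compounds share all atoms and bonds.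

Compound 3, `CC1CC/C(=N\Nc2ccc(C(=O)O)cc2)c2ncc(C(=O)O)c(=O)n21`, has not yet been measured in this assay. It differs from compound 1 by carboxy in place of ethoxy on an aromatic carbon. Among the measured compounds shown here, none of the measured steps touches this kind of change: the only known step concerns a drawn configuration at a saturated ring carbon, while the change to compound 3 swaps one group for another on the aromatic ring. The size and direction of the step in this assay therefore cannot be read from anything measured, and only a wide range can be given. Compound 3 is expected to give 6 umol/kg, from 1.2 umol/kg to 30 umol/kg. The expected step of a 3.8-fold higher number from compound 1 to compound 3 (0.57 log units; beyond the scatter) is thus uncertain and could fall within the scatter or well beyond it.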

Compound 3, dose for 50% inhibition: 7.6 umol/kg
Beside the measured number, compound 3's estimate is 1.3-fold (0.10 log units) below it; low and high end bracket the measured number.
By their numbers in this assay, from the lowest: compound 1; then compound 3; then compound 2.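

Replacing ethoxy with carboxy on the aromatic carbon, para to a large group, gives in this assay a 4.8-fold higher number from compound 1 to compound 3 (0.68 log units; beyond the scatter). Among the compounds shown here, until now the only step on record concerned a drawn configuration at a saturated ring carbon, so this is the first evidence that the group at this aromatic position also moves the number, and beyond the scatter. The exchange keeps the count of 3 heavy atoms while adding a hydrogen-bond donor and a double bond outside aromatic rings, yet nothing measured here bears on why the number shifts with this change.

As far as these compounds go, with only ethoxy and carboxy seen at this position, it remains open whether an amine, a methoxy group or a longer chain such as butoxy would give a number closer to that of compound 1 or that of compound 3. From the compounds shown here alone, it also remains open whether the same exchange would produce a step of similar size on compound 2, whose saturated ring carbon is drawn with a defined configuration.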